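The source may hold more compounds than are shown below. What is called first, only, known or untested is meant among the compounds shown, and "the series" means these compounds.

Values in a functional assay on BXPC-3 cells (Homo sapiens) for antiproliferative activity, read by sulforhodamine B assay, with a stated time of 72 h; a lower number here means a stronger inhibitor, a higher number a weaker inhibitor:
- compound 1 `CC(C)(C)c1[nH]cnc1/C=c1\[nH]c(=O)/c(=C/c2cccc(C(=O)c3cccnc3)c2)[nH]c1=O`: 4.05 nM
- compound 2 `CC(C)(C)c1[nH]cnc1/C=c1\[nH]c(=O)/c(=C/c2cccc(C(=O)c3ccncc3)c2)[nH]c1=O`: 23.8 nM

Compound 2 has the higher of the two numbers. The next structure is compound 3 `CC(C)(C)c1[nH]cnc1/C=c1\[nH]c(=O)/c(=C/c2cccc(C(=O)c3ccoc3)c2)[nH]c1=O`, with this change: furan-3-yl in place of pyridin-4-yl on a carbonyl carbon. In words, furan-3-yl replaces pyridin-4-yl on a carbonyl carbon. Within the data shown here, one measured step bears on it, at the same carbonyl carbon: a 5.9-fold higher number from compound 1 to compound 2 (0.77 log units; beyond the scatter). This step is modest but beyond the scatter. Among the measured compounds shown here, no furan-3-yl compound has a measured value, so the direction is tentative. The expected change is a 2.0-fold lower number from compound 2 to compound 3 (0.30 log units; within the scatter), smaller than that pyridinyl step. For compound 3 the estimated value is 12 nM, with an expected range of 3 nM to 50 nM.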

Compound 3, half-maximal inhibitory concentration: 9.41 nM
For compound 3 the middle estimate is 1.3-fold (0.11 log units) above the measured one; the range from low to high includes it.
By their numbers in this assay, from the lowest: compound 1; then compound 3; then compound 2.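

Exchanging pyridin-4-yl for furan-3-yl on the carbonyl carbon gives a 2.5-fold lower number from compound 2 to compound 3 (0.40 log units; beyond the scatter) in this assay, so a ring nitrogen is not required at this position and a five-membered aromatic ring is accepted there. Against pyridin-3-yl, furan-3-yl still shows a 2.3-fold higher number from compound 1 to compound 3 (0.37 log units; beyond the scatter), leaving compound 1 with the lowest number of the three. Nothing available here explains this order.

Still open, from the compounds shown here alone, is how a plain phenyl ring or a saturated ring amine such as piperidin-4-yl on the carbonyl carbon would compare. Going by these compounds, the effect of changing the carbonyl linker itself, for example to a methylene, also remains open.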